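This account rests on a few compounds, and the source may have more. Where it says the series, first, only, none or still open, it means among the compounds named here.

Values so far in a functional assay on HT-29 cells (Homo sapiens) for cytotoxicity, read by MTT assay, with a stated time of 3 days (on this read-out lower numbers stand for stronger inhibition and higher numbers for weaker inhibition), for the two measured compounds
Compound 1 `COc1cccc(-c2ccc(O)cc2)c1` gives 24 ug/mL
Compound 2 `Nc1cccc(-c2ccc(O)cc2)c1` gives 5.4 ug/mL

Compound 1 has the higher of these two numbers, so it is the weaker inhibitor of the pair. Compound 3 `COc1ccc(-c2ccc(O)cc2)cc1OC` is compound 1 with one change, (methoxy in place of hydrogen on an aromatic carbon), and it has not yet been measured. Within the data shown here, the only measured step nearby is a 4.4-fold lower number from compound 1 to compound 2 (0.65 log units; beyond the scatter), and it is a different kind of change: there a methoxy is replaced, whereas here one is added. It is therefore a weak guide, and no step beyond the scatter is expected in this assay, with neither direction favoured. For compound 3 the estimated value is 20 ug/mL (range 8 ug/mL to 50 ug/mL) in this assay. This estimate means an expected 1.2-fold lower number from compound 1 to compound 3 (0.08 log units; within the scatter) overall.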

Compound 3, half-maximal inhibitory concentration: 26 ug/mL
Compound 3: the middle estimate sits 1.3-fold (0.11 log units) below what was measured, and the stated range covers the measured number.
By their numbers in this assay, from the lowest: compound 2; then compounds 1 and 3 (each within the scatter of the next).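

Adding a methoxy on this aromatic carbon, ortho to the methoxy group already present, gives a 1.1-fold higher number from compound 1 to compound 3 (0.03 log units; within the scatter) in this assay, so this position accepts the extra group with no change that can be told from scatter. The earlier step, a 4.4-fold lower number from compound 1 to compound 2 (0.65 log units; beyond the scatter), came from replacing a methoxy and showed only that the read-out can respond to a change elsewhere on this ring. No measurement offers an explanation for the flat result here. As far as these compounds go, whether a fluorine or a carboxylic acid on this same carbon would also stay within the scatter remains open.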